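The source may report more compounds than this note shows. Statements on the series, on what has been measured and on what is new or still open speak of the compounds shown alone.

Values in a functional assay on MCF7 cells (Homo sapiens) for antiproliferative activity, read by MTT assay, with a stated time of 72 h (a lower number here means a stronger inhibitor, a higher number a weaker inhibitor), for the compounds measured so far:

compound 1 `CC(=O)O[C@H]1CC[C@]2(C)[C@H](CC[C@@](C)(O)[C@H]2CC[C@@H]2C(C)=CC[C@H]3[C@H](CC[C@]3(C)O)C2(C)C)OC1(C)C` gives 47900 nM
compound 2 `CC1=CC[C@H]2[C@H](CC[C@]2(C)O)C(C)(C)[C@@H]1CC[C@H]1[C@]2(C)CC[C@H](OC(=O)c3ccncc3)C(C)(C)O[C@H]2CC[C@@]1(C)O` gives 25300 nM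
compound 3 `COc1ccc(C(=O)O[C@H]2CC[C@]3(C)[C@H](CC[C@@](C)(O)[C@H]3CC[C@@H]3C(C)=CC[C@H]4[C@H](CC[C@]4(C)O)C3(C)C)OC2(C)C)cc1` gives 41700 nM

All three values lie close together, and compound 3 cannot be separated from either neighbour: the steps (a 1.1-fold lower number from compound 1 to compound 3 (0.06 log units; within the scatter)) and (a 1.6-fold higher number from compound 2 to compound 3 (0.22 log units; within the scatter)) both stay within the scatter.

Compound 4 `CC1=CC[C@H]2[C@H](CC[C@]2(C)O)C(C)(C)[C@@H]1CC[C@H]1[C@]2(C)CC[C@H](OC(=O)c3ccc(Cl)c(Cl)c3)C(C)(C)O[C@H]2CC[C@@]1(C)O` keeps the shared core and differs from compound 3 in a single place (3,4-dichlorophenyl in place of 4-methoxyphenyl on a carbonyl carbon), with 3,4-dichlorophenyl in place of 4-methoxyphenyl on a carbonyl carbon. The measured steps that bear on this are the other exchanges on that same carbonyl carbon. Going from methyl to pyridin-4-yl gave a small step (a 1.9-fold lower number from compound 1 to compound 2 (0.28 log units; within the scatter)), and the two steps to compound 3 given above were smaller still. Within the data shown here, none of them leaves the scatter, although no measured compound carries 3,4-dichlorophenyl. No step beyond the scatter is therefore expected in this assay. The expected change is small (a 1.3-fold lower number from compound 3 to compound 4 (0.10 log units; within the scatter)). For compound 4 the estimated value is 33000 nM, with an expected range from 16000 nM to 65000 nM.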

Compound 4, half-maximal inhibitory concentration: 11900 nM
Beside the measured number, compound 4's estimate is 2.8-fold (0.44 log units) above it, outside the stated range (below it).
By their numbers in this assay, from the lowest: compound 4; then compounds 2, 3 and 1 (each within the scatter of the next).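

In this assay an exchange on this carbonyl carbon now moves the number beyond the scatter, which no exchange among methyl, pyridin-4-yl and 4-methoxyphenyl did: 3,4-dichlorophenyl gives a 3.5-fold lower number from compound 3 to compound 4 (0.54 log units; beyond the scatter) and a 2.1-fold lower number from compound 2 to compound 4 (0.33 log units; beyond the scatter) and a 4.0-fold lower number from compound 1 to compound 4 (0.60 log units; beyond the scatter) in steps that are all modest. Compound 4 is thereby set apart from the other three, while compound 3 also carries a six-membered aromatic ring of carbon only, so such a ring alone does not go with the lower number. Nothing measured here accounts for this step. 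

A 4-chlorophenyl group on this carbonyl carbon would show whether one chlorine gives the same step as two. As far as these compounds go, whether an amine or a carboxylic acid in this place would lower the number further also remains open.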